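Compound 1 to compound 4: methoxy for trifluoromethyl

The source may report more compounds than this note shows. Statements on the series, on what has been measured and on what is new or still open speak of the compounds shown alone.

Values so far in an ADME assay on the whole organism (Mus musculus, strain CD1) for pharmacokinetics, at a dose of 2 mg/kg by the intravenous route (a higher number here means that more of the compound sits outside the plasma, a lower number that more of the compound stays in the plasma), for three compounds:

compound 1 `CN1CCC(Oc2ccc(N3C(=S)N(c4cnc(C#N)c(C(F)(F)F)c4)C(=O)C34CCC4)cc2)CC1` gives 12 L/kg
compound 2 `CN1CCC(Oc2ccc(N3C(=S)N(c4cnc(C#N)c(C(F)(F)F)c4)C(=O)C34CCC4)cn2)CC1` gives 7.69 L/kg
compound 3 `N#Cc1ncc(N2C(=O)C3(CCC3)N(c3ccc(CN4CCNCC4)cc3)C2=S)cc1C(F)(F)F` gives 16.8 L/kg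

Compound 1 at 12 L/kg has no clear rank in this small set, as the other two compounds both lie within the scatter of its value. Still unmeasured is compound 4 `COc1cc(N2C(=O)C3(CCC3)N(c3ccc(OC4CCN(C)CC4)cc3)C2=S)cnc1C#N` which differs from compound 1 by methoxy in place of trifluoromethyl on an aromatic carbon, ortho to a cyano group and meta to a large group.

For the measured compounds named here, the only measured step that starts from compound 1 is a 1.4-fold higher number from compound 1 to compound 3 (0.15 log units; within the scatter) and it lies elsewhere, with (piperazin-1-yl)methyl in place of (1-methylpiperidin-4-yl)oxy. Going by the values given here, no measured step touches the 6-cyano-5-(trifluoromethyl)pyridin-3-yl group, so the data give no direct reading of this change and only an indirect guide to its size. On that guide, no step beyond the scatter is expected in this assay and no firm direction can be given, so a wide range is kept. The expected step is a 1.2-fold lower number from compound 1 to compound 4 (0.08 log units; within the scatter) and remains a rough estimate. For compound 4 the estimated value is 10 L/kg with an expected range from 4.5 L/kg to 20 L/kg for the measurement still to come.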

Compound 4, volume of distribution at steady state: 3.7 L/kg
Compound 4: middle estimate off by 2.7-fold (0.43 log units), on the high side, and the stated range ends above it.
By their numbers in this assay, from the lowest: compound 4; then compounds 2, 1 and 3 (each within the scatter of the next, the first and the last beyond it).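

In this assay, for the compounds shown here, replacing trifluoromethyl with methoxy on the aromatic carbon ortho to a cyano group gives a 3.2-fold lower number from compound 1 to compound 4 (0.51 log units; beyond the scatter), the first change at this position and the first step from compound 1 that lies beyond the scatter. The only other measured step from compound 1, a 1.4-fold higher number from compound 1 to compound 3 (0.15 log units; within the scatter), lies elsewhere in the molecule and stays within the scatter, so this position is the one place shown where a single exchange clearly moves the read-out. No measurement available here accounts for the size or direction of this step.

With one replacement on one parent, the step cannot yet be assigned to the loss of trifluoromethyl or to the arrival of methoxy, and a methyl group, a chlorine atom or a longer alkoxy chain on the same carbon would help separate the two. As far as these compounds go, it also remains open whether the same exchange would give a step of similar size and direction on compound 2 or compound 3.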